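Aryl exchange from compound 2 to compound 3

This account rests on a few compounds, and the source may have more. Where it says the series, first, only, none or still open, it means among the compounds named here.

In a functional assay on SMMC-7721 cells (Homo sapiens) for inhibition, read by MTT assay, with a stated time of 48 h (on this read-out higher numbers stand for weaker inhibition and lower numbers for stronger inhibition), compound 1 (`Cc1ccc(NC(=O)Nc2cccc(-c3cccc4[nH]nc(N)c34)c2)cc1`) gives 4450 nM. Compound 2 (`Nc1n[nH]c2cccc(-c3cccc(NC(=O)Nc4ccc(F)c(F)c4)c3)c12`) gives 5880 nM, which lies within the scatter of compound 1, so the two numbers do not separate these compounds.

Compound 3 (`CC(C)c1cccc(NC(=O)Nc2cccc(-c3cccc4[nH]nc(N)c34)c2)c1`) keeps the shared core and carries 3-isopropylphenyl in place of 3,4-difluorophenyl on an amide-type nitrogen.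

Going by the values given here, one measured step bears on this change: a 1.3-fold higher number from compound 1 to compound 2 (0.12 log units; within the scatter). It exchanges 4-methylphenyl for 3,4-difluorophenyl on the same amide-type nitrogen and stays within the scatter. That single step is thin support, and 3-isopropylphenyl has not yet been measured in this series. On this evidence, no step beyond the scatter is expected in this assay, and no direction is favoured. The expected step is small: a 1.2-fold lower number from compound 2 to compound 3 (0.07 log units; within the scatter). The estimated value for compound 3 is 5000 nM, with an expected range of 2000 nM to 12000 nM.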

Compound 3, half-maximal inhibitory concentration: 280 nM
Compound 3: the middle estimate sits 18-fold (1.25 log units) above what was measured; the measured number lies below the stated range.
By their numbers in this assay, from the lowest: compound 3; then compounds 1 and 2 (each within the scatter of the next).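

In this assay this place, on an amide-type nitrogen whose other neighbour is the carbonyl carbon, proves able to shift the number strongly: 3-isopropylphenyl in place of 3,4-difluorophenyl gives (a 21-fold lower number from compound 2 to compound 3 (1.32 log units; beyond the scatter)). The earlier exchange (a 1.3-fold higher number from compound 1 to compound 2 (0.12 log units; within the scatter)) did not separate its two compounds, so the position had looked unresponsive to the aryl group on the strength of that one pair. Compared with 4-methylphenyl, 3-isopropylphenyl also gives a large step (a 16-fold lower number from compound 1 to compound 3 (1.20 log units; beyond the scatter)), which sets it apart from both earlier aryl groups, and the data in hand offer no measurement that accounts for this.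

The compounds shown leave open whether the lower number depends on the isopropyl group itself or on where it sits, a question that 4-isopropylphenyl, 3-methylphenyl and 3-tert-butylphenyl on the same nitrogen would address. Also open, on these data alone, is whether an aryl group carrying an oxygen or nitrogen substituent, such as 3-methoxyphenyl or 3-aminophenyl, keeps the step, and whether the step holds on any read-out other than this assay in these cells.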